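From 4-chlorophenyl to 3-chlorophenyl: an estimate for compound 3

The source may hold more compounds than are shown below. What is called first, only, known or untested is meant among the compounds shown, and "the series" means these compounds.

- compound 1 `CC(C)CCn1cnc2c(Nc3ccc(Cl)cc3)nc(N[C@H]3CC[C@H](N)CC3)nc21` gives 10200 nM
- compound 2 `CCCCCCn1cnc2c(Nc3ccc(O)cc3)nc(N[C@H]3CC[C@H](N)CC3)nc21` gives 24700 nM

Within the data shown here, only two compounds have been measured so far in a functional assay on HCC827 cells (Homo sapiens) for inhibition, read by fluorescence, with a stated time of 72 h (a lower number here means a stronger inhibitor of growth, a higher number a weaker inhibitor of growth), and they differ in more than one place. Compound 1 holds the lower of the two numbers at 10200 nM and compound 2 stands at 24700 nM with a gap beyond the usual scatter.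

Compound 3 `CC(C)CCn1cnc2c(Nc3cccc(Cl)c3)nc(N[C@H]3CC[C@H](N)CC3)nc21` has not yet been measured. It keeps the atoms of compound 1 but joins them differently, with 3-chlorophenyl in place of 4-chlorophenyl on a nitrogen on an aromatic ring while the rest of the structure stays the same.

Among the measured compounds shown here, no measured pair isolates this change, so the data give no direction for it. The expectation in this assay is therefore no shift beyond the scatter. The expected step is a 1.1-fold higher number from compound 1 to compound 3 (0.03 log units; within the scatter) and it remains an estimate until tested. For compound 3 the estimated value is 11000 nM with an expected range of 4500 nM to 26000 nM in this assay once measured.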

Compound 3, concentration for 50% growth inhibition: 10300 nM
Compound 3: the middle estimate sits 1.1-fold (0.03 log units) above what was measured; the measured number falls inside the stated range.
By their numbers in this assay, from the lowest: compounds 1 and 3 (each within the scatter of the next); then compound 2.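

In this assay, among these compounds, putting 3-chlorophenyl in place of 4-chlorophenyl on a nitrogen on an aromatic ring gives a 1.0-fold higher number from compound 1 to compound 3 (0.00 log units; within the scatter), the first reading of a single change, since the two compounds measured earlier differ in more than one place. With the rest of the structure held the same, the two chlorophenyl groups cannot be told apart in this growth read-out, so on this core and with this chain, the place of the chlorine on the phenyl ring, between these two options, leaves the value within the scatter. No independent measurement bears on why the two compounds read alike.

The compounds shown leave open whether this holds only for chlorine or also for other groups on that phenyl ring, such as a methoxy group, a carboxylic acid or an amine, and how a plain phenyl ring with no chlorine would read. They also leave open whether the same exchange would read alike with a different chain on the core, such as a longer chain or a shorter one.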